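The source may hold more compounds than are shown below. What is called first, only, known or untested is meant among the compounds shown, and "the series" means these compounds.

In a functional assay on MCF7 cells (Homo sapiens) for inhibition, read by XTT assay, with a stated time of 48 h (on this read-out higher numbers stand for weaker inhibition and lower numbers for stronger inhibition), compound 1 `CC(=O)OC/C(=C\c1ccccc1F)C(=O)c1ccccc1` gives 14600 nM and compound 2 `CC(=O)OC/C(=C\c1ccc(Cl)cc1Cl)C(=O)c1ccccc1` gives 8700 nM. Compound 3 `COc1ccc(C(=O)/C(=C/c2c(F)c(F)c(F)c(F)c2F)CCOC(C)=O)cc1` is recorded only as a limit of this assay, > 100000 nM, not as a number. Compound 3 therefore stands at the limit of > 100000 nM in this assay, at which 1 of the 3 values shown sits, and how far beyond that point it would fall is not known. Compound 4 `COc1ccc(C(=O)/C(=C/c2c(F)c(F)c(F)c(F)c2F)CC(C)OC(C)=O)cc1` differs from compound 3 by methyl in place of hydrogen on a saturated chain carbon bound to an oxygen next to a carbonyl group and a saturated chain carbon. Among the compounds with values here, no step between two measured compounds is available to calibrate this change in this assay, and compound 3 itself offers no number to start from. The expected step of a number no higher from compound 3 to compound 4 (the limit leaves the size open) in this assay stays within the scatter, with no movement in either direction that could be told apart from repeat measurements. The estimate for compound 4 in this assay is 100000 nM, between 30000 nM and 300000 nM, most likely reported again as a limit rather than a number.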

Compound 4, half-maximal inhibitory concentration: > 100000 nM
Compound 4: only a limit was reported; the forecaster's own chance of this, stated with the estimate: 70%; the middle value sits exactly at the limit.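

In this assay, within the data shown here, compound 3 and compound 4 are both recorded only as limits, and no step between them can be read: the limit of > 100000 nM in this assay, at which 2 of the 4 values shown sit.
The compounds shown leave open whether methyl in place of hydrogen at this place moves the read-out at all, in either direction.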